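The compounds below may be only part of what the source reports. "The series", "measured", "known", "first", "only" and "open" are said of these compounds alone.

Among the compounds with values here, in a functional assay on A549 cells (Homo sapiens) for antiproliferative activity, read by MTT assay, with a stated time of 72 h (a lower number here means a stronger inhibitor, a higher number a weaker inhibitor), compound 1 `CCOC(=O)C1CCN(CCCOc2cc3ncnc(Nc4ccc(C#N)cc4)c3cc2OC)CC1` gives 89900 nM and compound 2 `COc1cc2c(Nc3ccc(C#N)cc3)ncnc2cc1OCCCN1CCC(c2ccccc2)CC1` gives 9500 nM as the lower of the two numbers so far. Within the data shown here, the only measured step is a 9.5-fold lower number from compound 1 to compound 2 (0.98 log units; beyond the scatter) for phenyl in place of ethoxycarbonyl on a saturated ring carbon. The change to compound 3 `COc1cc2c(Nc3ccc(C#N)cc3)ncnc2cc1OCCCN1CCC(N(C)C)CC1` is dimethylamino in place of phenyl on a saturated ring carbon and amounts to dimethylamino in place of phenyl on a saturated ring carbon. Among the measured compounds shown here, the measured step bears on this only in part: the number in this assay moved with the group on this carbon and phenyl stood with the lower number, while dimethylamino has no measured precedent. With compound 2 at 9500 nM as the reference, losing phenyl is expected to raise the number modestly, by less than the measured step and perhaps not far beyond the scatter. For compound 3 the expected value is 22000 nM with an estimated range from 7000 nM to 70000 nM on present data. The estimated step is a 2.3-fold higher number from compound 2 to compound 3 (0.36 log units; beyond the scatter) and rests on a single comparison.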

Compound 3, half-maximal inhibitory concentration: 42400 nM
Beside the measured number, compound 3's estimate is 1.9-fold (0.28 log units) below it, and the stated range covers the measured number.
By their numbers in this assay, from the lowest: compound 2; then compound 3; then compound 1.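

Notes on the group on the saturated ring carbon, three ring bonds from the ring nitrogen: in this assay this position now carries three different groups, and the series no longer rests on a single comparison. The change from 4-phenylpiperidin-1-yl to 4-(dimethylamino)piperidin-1-yl gives a 4.5-fold higher number from compound 2 to compound 3 (0.65 log units; beyond the scatter) and so gives up part of the advantage held by phenyl, while dimethylamino in place of ethoxycarbonyl still gives a 2.1-fold lower number from compound 1 to compound 3 (0.33 log units; beyond the scatter) and the three groups therefore stand at three separate levels, with phenyl at the lowest number and ethoxycarbonyl at the highest. Nothing available explains this order of the groups.

Phenyl and dimethylamino differ at once in the aromatic ring, in heavy atoms and in the nitrogen, so the compounds shown do not tell which of these differences goes with the change in number. A cyclohexyl group would separate the ring's aromatic character from its size, while a benzyl group or a pyridyl ring on the same carbon would show whether compound 2 at 9500 nM can be improved on at this position.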